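A few compounds are considered here, and "the series" means these few. Any claim that something is new, unique, unknown or untested is made for them only; others in the source may bear on it.

Of the compounds shown here, three sharing one core have been measured in a functional assay on the whole organism (strain Swiss albino) for inhibition, with Mus musculus as the target, in the maximal electroshock model, with a stated time of 2 h, at a dose of 25 mg/kg by the intraperitoneal route; on this read-out lower numbers stand for less inhibition and higher numbers for more inhibition at the one dose given (going by the name of the read-out). Compound 1 `O=C1NC(=O)C(c2ccccc2Cl)CC1c1ccccc1Cl` carries a hydrogen on the ring nitrogen and gives 58.3% in this assay. Compound 2 `CN1C(=O)C(c2ccccc2Cl)CC(c2ccccc2Cl)C1=O` carries a methyl there and gives 61.7%. Compound 3 `Cc1ccccc1N1C(=O)C(c2ccccc2Cl)CC(c2ccccc2Cl)C1=O` carries a 2-methylphenyl there and gives 60.6%. Of the three numbers, compound 3 lies closest to compound 2, the step being a number 1.1 percentage points lower from compound 2 to compound 3 (within the scatter), and farther from compound 1, the step being a number 2.3 percentage points higher from compound 1 to compound 3 (within the scatter); each of these steps, like a number 3.4 percentage points higher from compound 1 to compound 2 (within the scatter), stays within the scatter, so the three compounds cannot be told apart on this read-out.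

Compound 4 `Cc1ccc(N2C(=O)C(c3ccccc3Cl)CC(c3ccccc3Cl)C2=O)cc1` keeps the same atoms joined differently: 4-methylphenyl in place of 2-methylphenyl on an amide-type nitrogen in a ring. Among the compounds with values here, the steps that bear on this change are those that alter the group on the ring nitrogen, from hydrogen to methyl, from hydrogen to 2-methylphenyl and from methyl to 2-methylphenyl, and none of them moved the number beyond the scatter. No change in this place has yet shifted the read-out, so no step beyond the scatter is expected here either. The step from compound 3 is expected to be a number 0.6 percentage points lower from compound 3 to compound 4 (within the scatter). Compound 4 is therefore estimated to give 60%, between 50% and 70%.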

Compound 4, a percentage reported as inhibition, in the whole organism at one dose (the size of the read-out at that dose, not a potency): 58.2%
Compound 4: middle estimate off by 1.8 percentage points, on the high side; the measured number falls inside the stated range.
By their numbers in this assay, from the lowest: compounds 4, 1, 3 and 2 (each within the scatter of the next).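

Shifting the methyl around the phenyl group, with the same atoms joined differently, gives a number 2.4 percentage points lower from compound 3 to compound 4 (within the scatter) in this assay, so this read-out does not separate 2-methylphenyl from 4-methylphenyl on the ring nitrogen. The comparison with the simpler groups at this place gives the same picture, with a number 3.5 percentage points lower from compound 2 to compound 4 (within the scatter) against methyl and a number 0.1 percentage points lower from compound 1 to compound 4 (within the scatter) against hydrogen. All four groups tried on the ring nitrogen, aromatic or not, therefore stay within the scatter of one another at this one dose, and nothing available speaks to why the number stays put at this position.

The compounds shown leave open whether a group of another kind on the ring nitrogen, such as an amine, a carboxylic acid or a longer chain, or an amine or carboxylic acid on the phenyl group, would move the number beyond the scatter. As far as these compounds go, since both 2-chlorophenyl groups are the same in all four compounds, and each compound is seen at a single dose, what a change in those groups would do and how the compounds differ in potency also remain open.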